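This account rests on a few compounds, and the source may have more. Where it says the series, first, only, none or still open, it means among the compounds named here.

Measured so far in an assay for inhibition of Amine oxidase [flavin-containing] B (Homo sapiens), read by fluorescence and spectrophotometry, using microsomes, with stated times of 30 min and 20 min; a higher number here means a weaker inhibitor, a lower number a stronger inhibitor: compound 1 `Clc1cccc(-c2nc(-c3cccc(C4=NCCN4)c3)no2)c1` gives 30 nM; compound 2 `c1cc(C2=NCCN2)cc(-c2noc(-c3cccs3)n2)c1` gives 1060 nM; compound 3 `c1csc(-c2noc(-c3ccc(C4=NCCN4)cc3)n2)c1` gives 890 nM.

Compound 2 and compound 3 are built from the same atoms joined differently; the difference between the two cores is not broken down here. Their two values lie within the usual scatter of each other, so nothing separates them. Compound 1 is compound 2 with one group swapped, (3-chlorophenyl in place of thiophen-2-yl on an aromatic carbon), and this gave a 35-fold lower number from compound 2 to compound 1 (1.55 log units; beyond the scatter).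

Compound 4 `Clc1cccc(-c2noc(-c3ccc(C4=NCCN4)cc3)n2)c1` has not yet been measured. It is compound 3 with the same kind of change, (3-chlorophenyl in place of thiophen-2-yl on an aromatic carbon). The place is not identical, though: in compound 1 the new group sits next to the ring nitrogen and next to the ring oxygen, two ring bonds from the ring nitrogen, whereas in compound 4 it sits between two ring nitrogen atoms, two ring bonds from the ring oxygen.

Because compound 2 to compound 1 showed a 35-fold lower number from compound 2 to compound 1 (1.55 log units; beyond the scatter), a step of similar direction is expected for compound 4, a 25-fold lower number from compound 3 to compound 4 (1.41 log units; beyond the scatter), though tempered for the changed place. Compound 4 is therefore estimated at 35 nM in this assay, most likely between 10 nM and 120 nM.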

Compound 4, half-maximal inhibitory concentration: 64 nM
Compound 4: the middle estimate sits 1.8-fold (0.26 log units) below what was measured; the measured number falls inside the stated range.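

In this assay, the swap from thiophen-2-yl to 3-chlorophenyl was read on a second core and gave a 14-fold lower number from compound 3 to compound 4 (1.14 log units; beyond the scatter). Set side by side, the two steps point the same way and cannot be told apart in size, which means that across these two cores the change carried over with both its direction and, within the usual scatter, its size: the same change on two cores in this assay, a 35-fold lower number (1.55 log units; beyond the scatter) from compound 2 to compound 1 and a 14-fold lower number (1.14 log units; beyond the scatter) from compound 3 to compound 4, 2.5-fold (0.40 log units) apart, within the scatter of two such steps This is still only two pairs of compounds and one swap; it does not show that the change would carry over to any other core, and it does not say why the number falls.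

The compounds shown leave open whether another group in that place, such as an amine, a carboxylic acid or a longer chain, would give a step of this kind. Also open, on these data alone, is how much of the step belongs to the chlorine and how much to the six-membered aromatic ring of carbon, a question that a plain phenyl group would address.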